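Amino in place of an aryl group on the shared core

This account rests on a few compounds, and the source may have more. Where it says the series, first, only, none or still open, it means among the compounds named here.

Compound 1 `O=C1Nc2ccc(S(=O)(=O)N3CCOCC3)cc2/C1=N/c1ccc(Br)cc1`: 44800 nM
Compound 2 `O=C1Nc2ccc(S(=O)(=O)N3CCOCC3)cc2/C1=N/c1cccc(C(F)(F)F)c1`: 41100 nM

Both compounds were tested in a functional assay on MCF7 cells (Homo sapiens) for cytotoxicity, read by sulforhodamine B assay, with a stated time of 24 h; a higher number here means a weaker inhibitor, a lower number a stronger inhibitor. Compound 2 stands level with compound 1, and the two cannot be ranked. Among the compounds with values here, the only measured step is a 1.1-fold lower number from compound 1 to compound 2 (0.04 log units; within the scatter).

The next compound, compound 3 `N/N=C1\C(=O)Nc2ccc(S(=O)(=O)N3CCOCC3)cc21`, keeps the shared core and differs from compound 2 at that same place, with amino in place of 3-(trifluoromethyl)phenyl on a double-bonded nitrogen.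

The measured step bears on this change only in part. It exchanged one phenyl group for another, whereas compound 3 has no ring at that place. Within the data shown here, no measured compound lacks a ring there, so the data say little about how large the change will be. No shift beyond the scatter is expected in this assay, although a wide range is needed in either direction. The expected result is a 1.1-fold higher number from compound 2 to compound 3 (0.04 log units; within the scatter). The estimated value for compound 3 is 45000 nM, with an expected range from 15000 nM to 130000 nM.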

Compound 3, half-maximal inhibitory concentration: 46800 nM
Estimate against measurement, compound 3: 1.0-fold (0.02 log units) below; the range from low to high includes it.
By their numbers in this assay, from the lowest: compounds 2, 1 and 3 (each within the scatter of the next).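

In this assay, the earlier pair had only exchanged one phenyl group for another on the double-bonded nitrogen, whereas the amino compound has no ring at that place. Even so, the step from the 3-(trifluoromethyl)phenyl group to amino (a 1.1-fold higher number from compound 2 to compound 3 (0.06 log units; within the scatter)) stays within the scatter, as does the step from the 4-bromophenyl group to amino (a 1.0-fold higher number from compound 1 to compound 3 (0.02 log units; within the scatter)), so among these three compounds, neither the presence of an aromatic ring nor the number of heavy atoms at this place separates the results. No evidence is available that would explain this result.

As far as these compounds go, it remains open whether any group at this place can move the number beyond the scatter, for example a carboxylic acid or a longer alkyl chain on the double-bonded nitrogen. From the compounds shown here alone, the shared core is the same in all three compounds, and how the number responds to a change elsewhere on that core also remains open.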